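Tosylation of a phenol across two inactive cores

The source may report more compounds than this note shows. Statements on the series, on what has been measured and on what is new or still open speak of the compounds shown alone.

Compound 2 `C=C1C[C@]23C[C@@]1(O)CC[C@H]2c1ccc(O)c(C)c1[C@@H]3Cn1cc(-c2ccc(F)cc2)nn1` carries a free hydroxy group on its aromatic ring. In a functional assay on HL-60 cells (Homo sapiens) for cytotoxicity, read by MTT assay, with a stated time of 4 days (a lower number here means a stronger inhibitor, a higher number a weaker inhibitor), compound 2 gives > 20000 nM, which is a limit of the assay rather than a number. Compound 1 `C=C1C[C@]23C[C@@]1(O)CC[C@H]2c1ccc(OS(=O)(=O)c2ccc(C)cc2)c(C)c1[C@@H]3Cn1cc(-c2ccc(F)cc2)nn1` differs from it by (4-methylphenyl)sulfonyl in place of hydrogen on an oxygen on an aromatic ring. In this assay compound 1 gives > 20000 nM, again only a limit. The step that the two limits leave unreadable from compound 2 to compound 1 therefore cannot be sized. Compound 3 `Cc1ccc(-c2cn(C[C@H]3c4c(ccc(O)c4C)[C@@H]4CC[C@@]5(C)C[C@]43CC5=O)nn2)cc1` rests on another core; the difference between the two cores is not broken down here. In this assay compound 3 gives > 20000 nM, also a limit. Compound 4 `Cc1ccc(-c2cn(C[C@H]3c4c(ccc(OS(=O)(=O)c5ccc(C)cc5)c4C)[C@@H]4CC[C@@]5(C)C[C@]43CC5=O)nn2)cc1` is the unmeasured partner of compound 3, made by the same change, ((4-methylphenyl)sulfonyl in place of hydrogen on an oxygen on an aromatic ring). Because the limit of > 20000 nM in this assay, at which 3 of the 3 values shown sit, holds every measured value, the step that the limit leaves unreadable from compound 3 to compound 4 is expected to be negligible. Compound 4 is expected to give 30000 nM, most likely reported once more as a limit.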

Compound 4, half-maximal inhibitory concentration: > 20000 nM
Compound 4 was reported as a limit (the forecaster's own chance of this, stated with the estimate: 85%); the middle value lies beyond the limit too.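

Compound 3 and compound 4 are both known only as limits in this assay, and the step between them cannot be read. As far as these compounds go, what (4-methylphenyl)sulfonyl on the oxygen does to cytotoxicity on either core stays open.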